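The source may hold more compounds than are shown below. What is called first, only, known or untested is meant among the compounds shown, and "the series" means these compounds.

Of the compounds shown here, two have been measured. Compound 1 `Cc1nc2cc(-c3ccccc3)nn2c(-c2cc(F)c3c(c2C)CCCO3)c1C(OC(C)(C)C)C(=O)O` gives 97% in an ADME assay on microsomes from liver (Rattus norvegicus), read by LC-MS, using NADPH, with a stated time of 10 min, tested at 0.5 uM; a lower number here means that less of the compound is left, a higher number that more of the compound is left. Compound 2 `Cc1ccccc1-c1cccc(-c2cc3nc(C)c([C@H](OC(C)(C)C)C(=O)O)c(-c4cc(F)c5c(c4C)CCCO5)n3n2)c1` carries a 2-methylphenyl on the aromatic ring that extends from the core and in this assay gives 97%. Compound 2 stands level with compound 1 at the digits printed, and the difference between the two is within the scatter, so no order between them can be stated.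

Compound 3 `Cc1nc2cc(-c3cccc(-c4ccncc4)c3)nn2c(-c2cc(F)c3c(c2C)CCCO3)c1[C@H](OC(C)(C)C)C(=O)O` is the next analogue to be measured in this assay. Relative to compound 2 the change is pyridin-4-yl in place of 2-methylphenyl on an aromatic carbon. The replacement sits on an aromatic carbon of a six-membered aromatic ring of carbon only.

Among the measured compounds shown here, with only two values in hand, both at the same reading, there is no step between measured compounds to lean on. Compound 3 is expected to stay near the level of compound 2, with a number 4 percentage points lower from compound 2 to compound 3 (within the scatter) as the step that this expectation means, that is, no change beyond the scatter. Compound 3 is therefore estimated at 93%, within a range from 78% to 100%.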

Compound 3, percent of the compound remaining: 94%
Estimate against measurement, compound 3: 1 percentage points below; the range from low to high includes it.
By their numbers in this assay, from the lowest: compounds 3, 1 and 2 (each within the scatter of the next).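

In this assay, among the compounds shown here, the replacement of 2-methylphenyl by pyridin-4-yl, on an aromatic carbon of a six-membered aromatic ring of carbon only and meta to a large group, appears as a number 3 percentage points lower from compound 2 to compound 3 (within the scatter) and is the only single-place step available so far. A carbon-only ring with no hydrogen-bond acceptor gives way here to a ring with one hetero atom and one hydrogen-bond acceptor, and the readings of the two compounds cannot be told apart, so at this position the assay separates neither the ring nitrogen nor the loss of the methyl-bearing ring. Nothing measured alongside these readings speaks to the reason for this result.

Still open, on these data alone, is whether the reading would hold with something other than a six-membered aromatic ring at this place, such as an amine, a carboxylic acid or a longer alkyl chain. Also open, as far as these compounds go, is whether pyridin-4-yl would read the same on another carbon of that ring, since this single step covers only one place and one replacement.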